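The source may hold more compounds than are shown below. What is called first, only, known or untested is meant among the compounds shown, and "the series" means these compounds.

Among the compounds with values here, compound 1 `COc1cc(N/C=C\C(=O)c2cn(-c3ccccc3)nc2-c2ccccc2)cc(OC)c1OC` is one of two compounds measured in an ADME assay on HaCaT cells (Homo sapiens) for antiproliferative activity, read by MTT assay, with a stated time of 48 h; a higher number here means a weaker inhibitor, a lower number a stronger inhibitor; in that assay compound 1 gives 36200 nM. Compound 2 `O=C(/C=C\Nc1ccc(Cl)cc1)c1cn(-c2ccccc2)nc1-c1ccc(F)cc1` gives 21300 nM in this assay. Of the two numbers, compound 1 has the higher, but the gap lies within the scatter, so the two compounds are not distinguished by it. Compound 3 `COc1cc(N/C=C\C(=O)c2cn(-c3ccccc3)nc2-c2cc(OC)c(OC)c(OC)c2)cc(OC)c1OC` differs from compound 1 in one place: 3,4,5-trimethoxyphenyl in place of phenyl on an aromatic carbon. Within the data shown here, no measured pair shows this change, so its step size is unknown; the expected step of a 1.2-fold lower number from compound 1 to compound 3 (0.08 log units; within the scatter) is not clearly beyond the scatter. The estimate for compound 3 in this assay is 30000 nM, with a range from 12000 nM to 75000 nM.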

Compound 3, half-maximal inhibitory concentration: 20900 nM
Beside the measured number, compound 3's estimate is 1.4-fold (0.16 log units) above it; low and high end bracket the measured number.
By their numbers in this assay, from the lowest: compounds 3, 2 and 1 (each within the scatter of the next).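

At the aromatic carbon next to the ring nitrogen, 3,4,5-trimethoxyphenyl in place of phenyl gives a 1.7-fold lower number from compound 1 to compound 3 (0.24 log units; within the scatter) in this assay. Within the data shown here, this position therefore accepts the added methoxy groups without a number that can be told apart from that of the phenyl compound, which the earlier compounds could not show. No supporting measurement gives a reason for this result. From the compounds shown here alone, whether an amine or a carboxylic acid on this aromatic carbon would move the number beyond the scatter remains open.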